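Replacing a Ring Nitrogen Substituent in a Receptor Antagonist Series

This account rests on a few compounds, and the source may have more. Where it says the series, first, only, none or still open, it means among the compounds named here.

The series shares one core, carried by compound 1 `Cc1cccc(CSc2nc3cc(NC(=O)C4CC4)ccc3n2C(C)C)c1`, compound 2 `COc1ccc(C#N)cc1CSc1nc2cc(NC(=O)C3CC3)ccc2n1C(C)C` and compound 3 `COc1ccc([N+](=O)[O-])cc1CSc1nc2cc(NC(=O)NC(C)(C)C)ccc2n1C1CC1`. In an assay on isolated protein for inhibition of Gonadotropin-releasing hormone receptor (Homo sapiens) (a higher number here means a weaker inhibitor, a lower number a stronger inhibitor), compound 1 gives 6500 nM, compound 2 gives 570 nM and compound 3 gives 79 nM. Within the data shown here, the only single-place step among them is an 11-fold lower number from compound 1 to compound 2 (1.06 log units; beyond the scatter), a change on the saturated chain carbon bound to a sulfur. Compound 3 stands lowest of the three numbers in this assay, with compound 2 nearest and compound 1 furthest from it.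

Compound 4 `COCCn1c(SCc2cc([N+](=O)[O-])ccc2OC)nc2cc(NC(=O)NC(C)(C)C)ccc21` differs from compound 3 in one place: 2-methoxyethyl in place of cyclopropyl on an aromatic nitrogen. Among the measured compounds shown here, no measured step touches the aromatic nitrogen, so the measured step from compound 1 to compound 2 does not bear on this change, and nothing among the three compounds shows how this assay responds there. In the absence of a step at this position, compound 4 is expected to stay near compound 3, with a step of a 1.9-fold higher number from compound 3 to compound 4 (0.28 log units; within the scatter). The estimate for compound 4 in this assay is therefore 150 nM, within a range of 40 nM to 600 nM.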

Compound 4, half-maximal inhibitory concentration: 57 nM
Estimate against measurement, compound 4: 2.6-fold (0.42 log units) above; the measured number falls inside the stated range.
By their numbers in this assay, from the lowest: compounds 4 and 3 (each within the scatter of the next); then compound 2; then compound 1.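

Among these compounds, on the aromatic nitrogen, 2-methoxyethyl in place of cyclopropyl gives a 1.4-fold lower number from compound 3 to compound 4 (0.14 log units; within the scatter) in this assay, the only measured step at this position. The three-membered carbon ring can therefore give way to an open chain carrying one hydrogen-bond acceptor without a change that this assay can separate from the scatter, at least with the other substituents of compound 3. No supporting measurement bears on why the two groups read alike.

The compounds shown leave open how this position would respond to an amine or a carboxylic acid at the end of the chain, or to a longer chain such as 3-methoxypropyl. They also leave open whether 2-methoxyethyl would be tolerated equally on the aromatic nitrogen of compound 2.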